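This account rests on a few compounds, and the source may have more. Where it says the series, first, only, none or still open, it means among the compounds named here.

Compound 1, `O=C1C=C(N2CCC2)C(=O)c2c1nc1n2[C@H]2OC[C@@H](O)[C@H]2OC1`, gives in a functional assay on HeLa cells (Homo sapiens) for inhibition, read by sulforhodamine B assay (on this read-out lower numbers stand for stronger inhibition and higher numbers for weaker inhibition), the limit > 16000 nM.
Compound 2, `O=C1C(NC2CCCC2)=CC(=O)c2c1nc1n2[C@H]2OC[C@@H](O)[C@H]2OC1`, gives in this assay the limit > 16000 nM.
Compound 3, `Cc1ccc(NC2=CC(=O)c3c(nc4n3[C@H]3OC[C@@H](O)[C@H]3OC4)C2=O)cc1`, gives in this assay 6590 nM.

Compound 1 stands at the edge of what this assay resolves, with no number of its own, a position described by the limit of > 16000 nM in this assay, at which 2 of the 3 values shown sit. The move to compound 4, `COc1cccc(NC2=CC(=O)c3nc4n(c3C2=O)[C@H]2OC[C@@H](O)[C@H]2OC4)c1`, is (3-methoxyphenyl)amino in place of azetidin-1-yl on a double-bonded ring carbon. For the measured compounds named here, no measured step covers this change itself. The closest guide is an at least 2.4-fold lower number from compound 2 to compound 3 (0.38 log units; beyond the scatter), where 4-methylphenyl in place of cyclopentyl on an amine nitrogen turned a limit into a number. Compound 4 likewise carries an aryl amine, so a drop from the limit to a value of the order of compound 3 is expected, with the estimated step being an at least 2.2-fold lower number from compound 1 to compound 4 (0.35 log units; beyond the scatter). Compound 4 is therefore expected at 7000 nM, in the range 2500 nM to 20000 nM.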

Compound 4, half-maximal inhibitory concentration: 4280 nM
The estimate for compound 4 lay 1.6-fold (0.21 log units) above the measured number; low and high end bracket the measured number.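

At this double-bonded ring carbon, (3-methoxyphenyl)amino in place of azetidin-1-yl gives an at least 3.7-fold lower number from compound 1 to compound 4 (0.57 log units; beyond the scatter). Compound 4 thus joins compound 3 as an aryl amine with a number, whereas the two compounds without an aryl group on the amine remain at the limit. The true size of this step stays unknown, because compound 1 has only a limit: the limit of > 16000 nM in this assay, at which 2 of the 4 values shown sit.

The change adds the aromatic ring and the amine hydrogen together, and the compounds shown do not separate the two. Also open, from the compounds shown here alone, is how a benzylamino group or a phenyl ring carrying a carboxylic acid would read here.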